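Hemolysis notes: furan amidine series, methoxy to chloro

A few compounds are considered here, and "the series" means these few. Any claim that something is new, unique, unknown or untested is made for them only; others in the source may bear on it.

Measured so far:
compound 1, `N=C(N)c1ccc(-c2ccc(-c3cc(Cl)cc(Cl)c3)s2)s1`: 6.7%
compound 2, `COc1ccc(-c2ccc(-c3ccc(C(=N)N)o3)o2)cc1`: 36.3%
compound 3, `COc1ccc(-c2ccc(-c3ccc(C(=N)N)s3)s2)cc1`: 63.7%

In an ADME assay on cells (Erythrocyte, Homo sapiens) for activation, read by hemolysis, with a stated time of 30 min, tested at 5 mM (on this read-out lower numbers stand for a weaker effect and higher numbers for a stronger effect at the one concentration tested), compound 2 stands second highest of the three numbers. Its nearest neighbour is compound 3, whose number lies higher by a margin beyond the scatter; the furthest is compound 1, whose number lies lower, again beyond the scatter. Going by the values given here, no two of the measured compounds differ in one place only, so no single structural step has a measured size in this assay; the three values can only be read side by side.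

Compound 4, `N=C(N)c1ccc(-c2ccc(-c3ccc(Cl)cc3)o2)o1`, is the next compound to be measured. Against compound 2 the change is chloro in place of methoxy on an aromatic carbon.

Among the compounds with values here, for this step a downward shift of moderate size is expected in this assay, probably beyond the scatter, because compound 1, the only measured compound bearing chloro groups, gives 6.7%. That basis is thin: compound 1 also differs from compound 2 in its core and in the number of chloro groups, so the direction is better supported than the size.

Compound 4 is estimated at 20%, with a range from 5% to 45%. This estimate means an expected step of a number 16.3 percentage points lower from compound 2 to compound 4 (beyond the scatter).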

Compound 4, a percentage reported as activity, at one concentration (the size of the read-out at that concentration, not a potency): 70.7%
The estimate for compound 4 lay 50.7 percentage points below the measured number, and the stated range ends below it.
By their numbers in this assay, from the lowest: compound 1; then compound 2; then compounds 3 and 4 (each within the scatter of the next).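

In this assay, going by these compounds alone, chloro in place of methoxy on an aromatic carbon, para to a large group, gives the first step of measured size: a number 34.4 percentage points higher from compound 2 to compound 4 (beyond the scatter). On the shared core, this position therefore tolerates chloro with a high number on this read-out, and the change is large enough to show that the position matters for hemolysis in this series. The low number of compound 1 cannot be read as a mark of chloro as such, since compound 1 differs from compound 4 in more than one place, and no measurement at hand accounts for the size or direction of the step.

As far as these compounds go, it remains open whether the same exchange would move the number in the same direction on the core of compound 3, and how other groups on this carbon, such as an amine, a carboxylic acid or a longer alkoxy chain, would stand against methoxy and chloro. From the compounds shown here alone, with a single concentration and a single stated time, it also remains open how this step would look at other concentrations.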